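This account rests on a few compounds, and the source may have more. Where it says the series, first, only, none or still open, it means among the compounds named here.

Three compounds of one shared core carry numbers in a physicochemical assay for lipophilicity, measured as octanol-water partition; on this read-out higher numbers stand for higher lipophilicity and lower numbers for lower lipophilicity. Compound 2 `C/C(CC(=O)Nc1nnc(/C=C/c2ccccc2)s1)=N\c1ccc([N+](=O)[O-])cn1` gives 4.13 in this assay, compound 3 `C/C(CC(=O)Nc1nnc(/C=C/c2ccccc2)s1)=N\c1ccccn1` gives 4.23 and compound 1 `CC(=O)Oc1ccccc1-c1nnc(NC(=O)C/C(C)=N/c2ccccn2)s1` gives 3.65. Going by the values given here, compound 2 stands second highest of the three: its nearest neighbour is compound 3, and the only single-point step that is known, a number 0.10 log units higher from compound 2 to compound 3 (within the scatter), lies within the scatter. Its furthest neighbour is compound 1, whose number is lower by an amount beyond the scatter.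

Compound 4 `CC(=O)Oc1ccccc1-c1nnc(NC(=O)C/C(C)=N/c2ccc([N+](=O)[O-])cn2)s1` has not been measured in this assay. It is reached from compound 2 by the change (2-acetoxyphenyl in place of 2-phenylethenyl on an aromatic carbon). Among the compounds with values here, no measured step covers exactly this exchange, and the nitro-to-hydrogen step between compound 2 and compound 3 says nothing about it directly. What bears on it is the pair of compound 3 and compound 1, which show the same exchange on the same core, and their two numbers sit apart by more than the scatter, the acetoxyphenyl compound lower. On that basis the step from compound 2 to compound 4 is expected to be downward, about a number 0.58 log units lower from compound 2 to compound 4 (beyond the scatter). Compound 4 is therefore estimated at 3.55 in this assay, within a range from 3.1 to 4.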

Compound 4, partition coefficient: 3.56
Beside the measured number, compound 4's estimate is 0.01 log units below it; the measured number falls inside the stated range.
By their numbers in this assay, from the lowest: compounds 4 and 1 (each within the scatter of the next); then compounds 2 and 3 (each within the scatter of the next).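

In this assay, the exchange of 2-phenylethenyl for 2-acetoxyphenyl on this aromatic carbon, next to the ring nitrogen and the ring sulfur, now has a measured step on the nitro-bearing compounds, a number 0.57 log units lower from compound 2 to compound 4 (beyond the scatter), and it points the same way as the printed values on the hydrogen-bearing pair, compound 3 at 4.23 and compound 1 at 3.65. The nitro-for-hydrogen exchange can now also be read with 2-acetoxyphenyl in this place, a number 0.09 log units lower from compound 1 to compound 4 (within the scatter), and like a number 0.10 log units higher from compound 2 to compound 3 (within the scatter) with 2-phenylethenyl, it stays within the scatter, so across these four compounds the group on this carbon separates the numbers while the exchange of nitro and hydrogen does not. No measurement shown explains why the exchange at this position gives a lower number.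

The compounds shown do not separate the contribution of the acetoxy group from that of the phenyl ring joined directly to the shared core, as a plain phenyl or a 2-hydroxyphenyl group in this place would. They also leave open how an amine, a carboxylic acid or a longer carbon chain on this carbon would read, and whether the exchange of nitro and hydrogen would remain within the scatter alongside such groups.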